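Swapping a Hydroxypentyl Chain for Phenyl on the Core

The source may report more compounds than this note shows. Statements on the series, on what has been measured and on what is new or still open speak of the compounds shown alone.

Compound 2 `CSc1nc(NCCCCCO)c2ccccc2n1` carries a 5-hydroxypentyl chain on the nitrogen attached to the shared core. In an ADME assay on 184B5 cells (Homo sapiens) for cytotoxicity, read by MTT assay, with a stated time of 72 h (a higher number here means a weaker inhibitor of growth, a lower number a stronger inhibitor of growth), compound 2 gives > 100000 nM, which is a limit of the assay rather than a number. Compound 1 `CSc1nc(NCc2ccccc2)c2ccccc2n1` gives > 100000 nM in this assay, also a limit. The step that the two limits leave unreadable from compound 1 to compound 2 therefore cannot be sized. Compound 3 `CSc1nc(Nc2ccccc2)c2ccccc2n1` differs from compound 2 by phenyl in place of 5-hydroxypentyl on a nitrogen on an aromatic ring. With both measured values sitting at the limit of > 100000 nM in this assay, at which 2 of the 2 values shown sit, no size or direction can be read for this change. Compound 3 is expected to give 100000 nM, from 30000 nM to 300000 nM. The expected step of a number no higher from compound 2 to compound 3 (the limit leaves the size open) is thus none beyond the scatter.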

Compound 3, concentration for total growth inhibition: > 100000 nM
Compound 3 was reported as a limit; the forecaster's own chance of this, stated with the estimate: 75%; the middle value sits exactly at the limit.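

Compound 2 and compound 3 both stand at a limit in this assay, so no step between them can be read: the limit of > 100000 nM in this assay, at which 3 of the 3 values shown sit.

How strongly any of these compounds inhibits growth, and whether the group on this nitrogen matters, stays open.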